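Extending the Butyl Chain of Compound 1 with a Pyrimidinylsulfanyl Group

The compounds below may be only part of what the source reports. "The series", "measured", "known", "first", "only" and "open" are said of these compounds alone.

Within the data shown here, compound 1 `CCCCn1nc(-c2cccnc2)c2ccccc2c1=O` is one of two compounds measured in a functional assay (trachea) with Cavia porcellus as the target (a higher number here means a weaker inhibitor, a lower number a stronger inhibitor), and it holds the lower of the two numbers: in this assay compound 1 gives 2290 nM. Its companion, compound 2 `O=C(c1cccs1)n1nc(-c2cccnc2)c2ccccc2c1=O`, gives 12300 nM. Among the measured compounds shown here, the one measured step, a 5.4-fold higher number from compound 1 to compound 2 (0.73 log units; beyond the scatter), swaps the whole butyl chain for a (thiophen-2-yl)carbonyl group and makes the inhibitor weaker.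

Compound 3 `O=c1c2ccccc2c(-c2cccnc2)nn1CCCCSc1ncccn1` keeps the butyl chain of compound 1 and instead changes its far end: (pyrimidin-2-yl)sulfanyl in place of hydrogen on a saturated chain carbon, four bonds along the chain from an aromatic nitrogen. This is a different kind of change from the one seen in the measured step, which removed the chain rather than lengthening it, so that step gives no direct guidance on how a (pyrimidin-2-yl)sulfanyl group at the end of the chain will behave. For the measured compounds named here, with no step of the same kind to lean on, the most defensible expectation is a number close to that of compound 1, with wide uncertainty in either direction. In this assay compound 3 is therefore estimated at 2000 nM, within a range of 500 nM to 8000 nM, which amounts to an expected step of a 1.1-fold lower number from compound 1 to compound 3 (0.06 log units; within the scatter).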

Compound 3, half-maximal inhibitory concentration: 6170 nM
For compound 3 the middle estimate is 3.1-fold (0.49 log units) below the measured one, and the stated range covers the measured number.
By their numbers in this assay, from the lowest: compound 1; then compounds 3 and 2 (each within the scatter of the next).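

In this assay, the far end of the butyl chain proves sensitive to change: adding (pyrimidin-2-yl)sulfanyl in place of hydrogen on a saturated chain carbon, four bonds along the chain from an aromatic nitrogen, gives a 2.7-fold higher number from compound 1 to compound 3 (0.43 log units; beyond the scatter) and so a modestly weaker inhibitor. Among these compounds, until now, the only step at this nitrogen had replaced the whole chain; this one keeps the butyl chain and extends it, and it also raises the number, so compound 1 with its plain butyl group holds the lowest number of the three compounds. No measurement shown here accounts for the weaker result of compound 3.

As far as these compounds go, what remains open is which part of the added group matters, since the sulfur link, the pyrimidine ring and the extra length all arrive together in this single change. A plain longer chain such as hexyl, a phenylsulfanyl group, or an amine or a carboxylic acid at the same chain end would help separate these parts and show whether any group there can match or improve on compound 1.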